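The source may report more compounds than this note shows. Statements on the series, on what has been measured and on what is new or still open speak of the compounds shown alone.

Of the compounds shown here, three sharing one core have been measured in a functional assay on RT-112 cells (Homo sapiens) for antiproliferative activity, read by MTT assay, with a stated time of 72 h; on this read-out lower numbers stand for stronger inhibition of growth and higher numbers for weaker inhibition of growth. Compound 1 (`COc1cc(Nc2ncnc3c(NC(=O)Nc4cc(Cl)c(Cl)cc4Cl)cccc23)cc(OC)c1`) gives 4890 nM, compound 2 (`COc1cc(Nc2ncnc3c(NC(=O)Nc4cc(F)cc(F)c4)cccc23)cc(OC)c1`) gives 2630 nM, and compound 3 (`COc1cc(Nc2ncnc3c(NC(=O)Nc4ccc(F)cc4C(F)(F)F)cccc23)cc(OC)c1`) gives 2970 nM. Compound 3 therefore stands level with the other two, with measured gaps of a 1.1-fold higher number from compound 2 to compound 3 (0.05 log units; within the scatter) and a 1.6-fold lower number from compound 1 to compound 3 (0.22 log units; within the scatter).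

Compound 4 (`COc1cc(Nc2ncnc3c(NC(=O)Nc4ccc(Cl)cc4Cl)cccc23)cc(OC)c1`) has not yet been measured. It carries 2,4-dichlorophenyl in place of 4-fluoro-2-(trifluoromethyl)phenyl on an amide-type nitrogen. Going by the values given here, the steps that bear on this change are the other exchanges of the group at the same nitrogen. Beyond the two gaps already given, there is a 1.9-fold lower number from compound 1 to compound 2 (0.27 log units; within the scatter). All three stay within the scatter, so no step beyond the scatter is expected in this assay for this exchange. The step expected is a 1.1-fold higher number from compound 3 to compound 4 (0.05 log units; within the scatter). Compound 4 is estimated at 3300 nM, within an expected range of 1500 nM to 7000 nM.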

Compound 4, concentration for 50% growth inhibition: 3060 nM
Compound 4: the middle estimate sits 1.1-fold (0.03 log units) above what was measured; measured number inside the range.
By their numbers in this assay, from the lowest: compounds 2, 3, 4 and 1 (each within the scatter of the next).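

In this assay, setting 2,4-dichlorophenyl in place of 4-fluoro-2-(trifluoromethyl)phenyl on the amide-type nitrogen gives a 1.0-fold higher number from compound 3 to compound 4 (0.01 log units; within the scatter), and the two other new steps, a 1.2-fold higher number from compound 2 to compound 4 (0.07 log units; within the scatter) and a 1.6-fold lower number from compound 1 to compound 4 (0.20 log units; within the scatter), also remain within the scatter. The fourth group at this nitrogen therefore leaves the read-out where the first three put it, and the removal of a single chloro from an aromatic carbon, a smaller exchange than any seen before, does not separate the pair either. Nothing available offers an explanation for this flat picture.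

As far as these compounds go, all four groups are halogen-bearing phenyl rings, so it stays open whether any exchange at this nitrogen can move the number beyond the scatter. An unsubstituted phenyl, a methoxyphenyl, a phenyl carrying an amine or a carboxylic acid, or a cyclohexyl or longer alkyl chain could each answer that.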